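Removing the phenyl group from compound 1

The source may report more compounds than this note shows. Statements on the series, on what has been measured and on what is new or still open speak of the compounds shown alone.

compound 1 `O=C1CS/C(=N/Nc2nncc3ccccc23)N1c1ccccc1`: 30 nM
compound 2 `O=S(=O)(Nc1ncccn1)c1ccc(Nc2nncc3ccccc23)cc1`: 33 nM
compound 3 `O=S(=O)(Nc1nccs1)c1ccc(Nc2nncc3ccccc23)cc1`: 39 nM

In a functional assay on NCI-H460 cells (Homo sapiens) for antiproliferative activity, read by sulforhodamine B assay, with a stated time of 72 h (on this read-out lower numbers stand for stronger inhibition and higher numbers for weaker inhibition), compound 1 stands level with compound 2 and compound 3, since all three values lie within the scatter of one another. The next compound, compound 4 `O=C1CS/C(=N/Nc2nncc3ccccc23)N1`, differs from compound 1 as follows: hydrogen in place of phenyl on an amide-type nitrogen in a ring. This is hydrogen in place of phenyl on an amide-type nitrogen in a ring. Among the measured compounds shown here, only one measured step is available, a 1.2-fold higher number from compound 2 to compound 3 (0.07 log units; within the scatter). It lies within the scatter, but it concerns a group on a sulfonamide nitrogen, so it bears only weakly on this change. For the measured compounds named here, no measured compound shows the loss of a whole ring, and the direction in this assay therefore remains an expectation with a wide margin. Weaker inhibition than compound 1 at 30 nM is considered the more likely outcome, and the expected step is a 2.3-fold higher number from compound 1 to compound 4 (0.37 log units; beyond the scatter). For compound 4 the estimated value is 70 nM, with an expected range of 20 nM to 300 nM.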

Compound 4, half-maximal inhibitory concentration: 19 nM
The estimate for compound 4 lay 3.7-fold (0.57 log units) above the measured number; the whole stated range lies above it.
By their numbers in this assay, from the lowest: compounds 4, 1, 2 and 3 (each within the scatter of the next, the first and the last beyond it).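

In this assay, hydrogen in place of phenyl on the amide-type nitrogen in the ring gives a 1.6-fold lower number from compound 1 to compound 4 (0.20 log units; within the scatter) and so shows that this position tolerates the removal of the whole phenyl ring, with its 6 heavy atoms. Compound 1 alone could not separate the contribution of the phenyl from that of the rest of the molecule, whereas this pair shows activity held at the same level within the scatter with only a hydrogen on this nitrogen. No available data explain why the step is this small.

The compounds shown leave open how a methyl group, a longer alkyl chain or a chain ending in a carboxylic acid or an amine would behave on this nitrogen. They also leave open whether a phenyl ring carrying a further group, such as methoxy or chloro, would stay at this level.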